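This account rests on a few compounds, and the source may have more. Where it says the series, first, only, none or still open, it means among the compounds named here.

Three compounds share one core and differ only in the aryl group carried by the ring nitrogen. In a functional assay on CHO cells with adenosine receptor A1 (Homo sapiens) as the target, read by cAMP accumulation and immunoassay, with a stated time of 6 min, tested at 1 uM (a higher number here means a weaker effect of the compound at the concentration tested, a lower number a stronger effect), compound 1 `Nc1scc(CN2CCN(c3cccc(Cl)c3Cl)CC2)c1C(=O)c1ccc(Cl)cc1` gives -57%, and compound 2 `Nc1scc(CN2CCN(c3cccc(C(F)(F)F)c3)CC2)c1C(=O)c1ccc(Cl)cc1` gives -72%. Compound 3 `Nc1scc(CN2CCN(c3ccccc3Cl)CC2)c1C(=O)c1ccc(Cl)cc1` gives -5.2%, which places it highest of the three, that is, with the weakest effect: the step of a number 51.8 percentage points higher from compound 1 to compound 3 (beyond the scatter) is large, the step of a number 66.8 percentage points higher from compound 2 to compound 3 (beyond the scatter) larger still, whereas the step of a number 15 percentage points lower from compound 1 to compound 2 (beyond the scatter) is modest. Compound 4 `Nc1scc(CN2CCN(c3cc(Cl)ccc3Cl)CC2)c1C(=O)c1ccc(Cl)cc1` is compound 3 with a single change, (chloro in place of hydrogen on an aromatic carbon), so that 2-chlorophenyl becomes 2,5-dichlorophenyl. The step from compound 1 to compound 3 bears most directly on this, since there a chloro on the same ring was replaced by hydrogen and the number rose by a large amount; adding a chloro back, though at a different place, is therefore expected to lower the number again in this assay, probably by a large step, though the new place makes the size uncertain. Compound 4 is expected to give -35%, in a range from -70% to 0%. The expected step is a number 29.8 percentage points lower from compound 3 to compound 4 (beyond the scatter).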

Compound 4, a percentage reported as activity, at one concentration (the size of the read-out at that concentration, not a potency): -42%
Estimate against measurement, compound 4: 7 percentage points above; measured number inside the range.
By their numbers in this assay, from the lowest: compound 2; then compound 1; then compound 4; then compound 3.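

In this assay the added chloro, para to a chloro group, gives a number 36.8 percentage points lower from compound 3 to compound 4 (beyond the scatter) and so a stronger effect; the 2,3-dichlorophenyl group of compound 1 is therefore not the only dichlorophenyl pattern that lowers the number well below that of compound 3. The pattern still matters, with a number 15 percentage points higher from compound 1 to compound 4 (beyond the scatter) on going from 2,3-dichlorophenyl to 2,5-dichlorophenyl, while a number 30 percentage points higher from compound 2 to compound 4 (beyond the scatter) leaves the 3-(trifluoromethyl)phenyl group of compound 2 with the lowest number of the four. No measurement shown here explains any of these steps.

Going by these compounds, it remains open whether a methoxy group or an amine on this same aromatic carbon would lower the number as the chloro does. A methyl group there is equally untested among the compounds shown.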